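This account rests on a few compounds, and the source may have more. Where it says the series, first, only, none or still open, it means among the compounds named here.

Within the data shown here, in a physicochemical assay for solubility, at pH 7.4 (a higher number here means a more soluble compound, a lower number a less soluble compound), compound 2 (`CCCOc1cccc(-c2[nH]c3cc(OC)ccc3c(=O)c2C(=O)OCC)c1`) gives 5800 nM, the higher of the two numbers so far, and compound 1 (`CCOC(=O)c1c(-c2cccc(-c3ccccc3)c2)[nH]c2cc(OC)ccc2c1=O`) gives 200 nM. The next structure, compound 3 (`CCOC(=O)c1c(-c2cccc(Oc3ccccc3)c2)[nH]c2cc(OC)ccc2c1=O`), alters compound 2 in one place: phenyl in place of propyl on an oxygen on an aromatic ring. In words, this is phenyl in place of propyl on an oxygen on an aromatic ring, or propoxy to phenoxy.

Among the measured compounds shown here, only one measured step bears on this change: a 29-fold higher number from compound 1 to compound 2 (1.46 log units; beyond the scatter), large and beyond the scatter, with propoxy in place of phenyl on an aromatic carbon. The match is partial. Compound 3 carries a second phenyl ring as compound 1 (200 nM) does, but it keeps the oxygen of compound 2. For the measured compounds named here, no measured pair isolates that oxygen, so the size of the move remains uncertain. A large part of the measured step is expected to reverse, giving a clear drop in this assay that stays somewhat smaller than the measured step. The expected change is a 9.7-fold lower number from compound 2 to compound 3 (0.99 log units; beyond the scatter). For compound 3 the estimated value is 600 nM, with an expected range from 150 nM to 2000 nM.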

Compound 3, solubility: 4300 nM
Compound 3: middle estimate off by 7.2-fold (0.86 log units), on the low side; the measured number lies above the stated range.
By their numbers in this assay, from the lowest: compound 1; then compounds 3 and 2 (each within the scatter of the next).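

In this assay, a 1.3-fold lower number from compound 2 to compound 3 (0.13 log units; within the scatter), so on the oxygen on an aromatic ring, phenyl and propyl cannot be told apart, and the second phenyl ring of compound 3 does not by itself go with the low number of compound 1. With the ring present in both compounds, a 22-fold higher number from compound 1 to compound 3 (1.33 log units; beyond the scatter), which leaves compound 1, the only one of the three without an oxygen on that aromatic carbon, apart from compounds 2 and 3, a pattern that holds for these three compounds only and that none of them goes against. Nothing measured here gives a reason for either step.

Whether the oxygen itself carries the difference remains unsettled, since a single comparison sets phenoxy against phenyl, and a methylene or an amine link in place of the oxygen would test how far the step depends on that atom. On these data alone, it is also open whether the flat response on the oxygen extends to a longer chain than propyl, or to a phenyl bearing a carboxylic acid or an amine.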